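Chloro addition on the core of compound 2

The compounds below may be only part of what the source reports. "The series", "measured", "known", "first", "only" and "open" are said of these compounds alone.

Measured so far:
compound 1 `ClCc1ccccc1Cn1cnc2c(Cl)nc(Cl)nc21`: 2950 nM
compound 2 `ClCc1cccc(Cn2cnc3ncnc(Cl)c32)c1`: 20000 nM

In a functional assay on OVCAR-5 cells (Homo sapiens) for cytotoxicity, read by sulforhodamine B assay, with a stated time of 48 h (a lower number here means a stronger inhibitor of growth, a higher number a weaker inhibitor of growth), compound 2 gives 20000 nM, the higher of the two numbers shown, with compound 1 the lower and the gap between them beyond the scatter. Compound 3 `ClCc1cccc(Cn2cnc3nc(Cl)nc(Cl)c32)c1` carries chloro in place of hydrogen on an aromatic carbon. Within the data shown here, no step of this exact kind has been measured. Compound 1, which carries two chloro groups on the core, gives 2950 nM in this assay, so a move toward a lower number is expected for compound 3, of moderate size, beyond the scatter. The step of a 3.3-fold lower number from compound 2 to compound 3 (0.52 log units; beyond the scatter) is the expected change. Compound 3 is expected to give 6000 nM, in the range 2000 nM to 18000 nM.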

Compound 3, concentration for total growth inhibition: 3230 nM
For compound 3 the middle estimate is 1.9-fold (0.27 log units) above the measured one; measured number inside the range.
By their numbers in this assay, from the lowest: compounds 1 and 3 (each within the scatter of the next); then compound 2.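

In this assay, chloro in place of hydrogen on the aromatic carbon between two ring nitrogen atoms gives a 6.2-fold lower number from compound 2 to compound 3 (0.79 log units; beyond the scatter), the first step read at this position. The position therefore accepts a chloro group, and the number moves toward stronger inhibition of growth by more than the scatter. Nothing available bears on the origin of this step.

From the compounds shown here alone, whether an amine or a methyl group on this same carbon moves the number in the same direction stays open. One step also sets no trend across groups at this position.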